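This account rests on a few compounds, and the source may have more. Where it says the series, first, only, none or still open, it means among the compounds named here.

Measured so far:
- compound 1 `C/C=C1/[C@H](O[C@@H]2O[C@H](CO)[C@@H](O)[C@H](O)[C@H]2O)OC=C(C(=O)OC)[C@H]1CC(=O)OCCc1ccc(OC)c(OC)c1`: > 15000 nM
- compound 2 `C/C=C1/[C@H](O[C@@H]2O[C@H](COC(C)=O)[C@@H](OC(C)=O)[C@H](OC(C)=O)[C@H]2OC(C)=O)OC=C(C(=O)OC)[C@H]1CC(=O)OC`: > 15000 nM

In a functional assay on SK-BR-3 cells (Homo sapiens) for antiproliferative activity, read by MTT assay, with a stated time of 72 h (a lower number here means a stronger inhibitor, a higher number a weaker inhibitor), compound 1 gives > 15000 nM, which is a limit of the assay and not a number. Compound 2 likewise gives > 15000 nM, again a limit. Compound 1 therefore stands at the limit of > 15000 nM in this assay, at which 2 of the 2 values shown sit, so no numbered value is available for the pair. Compound 3 `C/C=C1/[C@H](O[C@@H]2O[C@H](CO)[C@@H](O)[C@H](O)[C@H]2O)OC=C(C(=O)OC)[C@H]1CC(=O)OCCC(C)C` differs from compound 1 by isopropyl in place of 3,4-dimethoxyphenyl on a saturated chain carbon, two bonds along the chain from an oxygen next to a carbonyl group. Among the measured compounds shown here, no measured step covers this change. The step that the limit leaves unreadable from compound 1 to compound 3 is expected to be none beyond the scatter, with a limit the likely outcome. Compound 3 is estimated at 20000 nM (range 8000 nM to 60000 nM).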

Compound 3, half-maximal inhibitory concentration: 9020 nM
The estimate for compound 3 lay 2.2-fold (0.35 log units) above the measured number; the measured number falls inside the stated range.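

In this assay, among the compounds shown here, compound 3 gives 9020 nM, the first numbered value, so a measurable value at this place does not need the aromatic ring of 3,4-dimethoxyphenyl. The change to isopropyl gives an at least 1.6-fold lower number from compound 1 to compound 3 (0.22 log units; that floor lies within the scatter). The true size of this step stays unknown, as compound 1 carries a limit and not a number: the limit of > 15000 nM in this assay, at which 2 of the 3 values shown sit.

Open, as far as these compounds go, is whether a longer chain, an amine or a carboxylic acid at this place would move the number further. Also open, from the compounds shown here alone, is how far compound 1 really lies from compound 3.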